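Moving the trifluoromethyl group on the triazole-linked phenyl ring

The compounds below may be only part of what the source reports. "The series", "measured", "known", "first", "only" and "open" are said of these compounds alone.

The series shares a diaryl urea core and a triazole that carries a variable aryl group on one of its ring nitrogens. Compound 1 `COc1ccc(-n2cc(COc3cccc(NC(=O)Nc4ccc(Cl)c(C(F)(F)F)c4)c3)nn2)cc1` gives 4680 nM in a functional assay on HepG2 cells (Homo sapiens) for inhibition, read by MTT assay, with a stated time of 72 h; on this read-out lower numbers stand for stronger inhibition and higher numbers for weaker inhibition. Compound 2 `CC(C)c1ccccc1-n1cc(COc2cccc(NC(=O)Nc3ccc(Cl)c(C(F)(F)F)c3)c2)nn1` gives 1900 nM, and compound 3 `O=C(Nc1cccc(OCc2cn(-c3cccc(C(F)(F)F)c3)nn2)c1)Nc1ccc(Cl)c(C(F)(F)F)c1` gives 1270 nM. Among these three numbers compound 2 stands second highest: compound 3 is its nearest neighbour, with a 1.5-fold lower number from compound 2 to compound 3 (0.17 log units; within the scatter), while compound 1 is furthest away, with a 2.5-fold lower number from compound 1 to compound 2 (0.39 log units; beyond the scatter).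

Compound 4 `O=C(Nc1cccc(OCc2cn(-c3ccc(C(F)(F)F)cc3)nn2)c1)Nc1ccc(Cl)c(C(F)(F)F)c1` differs from compound 2 in one place: 4-(trifluoromethyl)phenyl in place of 2-isopropylphenyl on an aromatic nitrogen. Going by the values given here, two measured steps bear on this change. Replacing the 4-methoxyphenyl of compound 1 by an aryl group bearing a trifluoromethyl substituent produced a 3.7-fold lower number from compound 1 to compound 3 (0.57 log units; beyond the scatter), whereas the step between the two aryl groups most comparable to those of compound 2 and compound 4 was a 1.5-fold lower number from compound 2 to compound 3 (0.17 log units; within the scatter), a step that stays within the scatter. Among the compounds with values here, compound 4 carries the trifluoromethyl group at a different ring position from compound 3, and no measured pair isolates that shift, so the expectation rests on the closeness of compound 2 and compound 3.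

Compound 4 is therefore expected to show a 1.4-fold lower number from compound 2 to compound 4 (0.13 log units; within the scatter), a step not clearly beyond the scatter. The estimated value for compound 4 is 1400 nM, with a likely range from 600 nM to 3500 nM.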

Compound 4, half-maximal inhibitory concentration: 1800 nM
For compound 4 the middle estimate is 1.3-fold (0.11 log units) below the measured one; the range from low to high includes it.
By their numbers in this assay, from the lowest: compounds 3, 4 and 2 (each within the scatter of the next); then compound 1.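

In this assay, going by these compounds alone, exchanging 3-(trifluoromethyl)phenyl for 4-(trifluoromethyl)phenyl on the aromatic nitrogen gives a 1.4-fold higher number from compound 3 to compound 4 (0.15 log units; within the scatter), so this read-out does not separate the two placements of the trifluoromethyl group, a shift that no earlier pair had isolated. The 2-isopropylphenyl group is not separated from 4-(trifluoromethyl)phenyl either, with a 1.1-fold lower number from compound 2 to compound 4 (0.02 log units; within the scatter), so two aryl groups with different substituents give numbers within the scatter of each other at this nitrogen. Trifluoromethyl in place of methoxy on the same ring gives a 2.6-fold lower number from compound 1 to compound 4 (0.41 log units; beyond the scatter), a modest step, which leaves compound 1 as the only one of the four set apart from the others by steps beyond the scatter.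

Nothing in the data shown explains why these aryl groups compare as they do. From the compounds shown here alone, it remains open whether an amine, a carboxylic acid or a nitrile on this aryl ring would give a number beyond the scatter of compound 3 and compound 4, or whether the step from the methoxy group of compound 1 is as large as changes at this position become.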